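From 4-bromophenyl to 3-nitrophenyl: compound 4 in prospect

The source may hold more compounds than are shown below. What is called first, only, known or untested is meant among the compounds shown, and "the series" means these compounds.

In a functional assay on MCF7 cells (Homo sapiens) for cytotoxicity, read by MTT assay, with a stated time of 96 h (on this read-out higher numbers stand for weaker inhibition and lower numbers for stronger inhibition), compound 1 (`COc1cc(C(=O)c2cn(-c3ccccc3)cc2-c2ccccc2C)cc(OC)c1OC`) gives 190 nM while compound 2 (`COc1cc(C(=O)c2cn(-c3ccccc3)cc2-c2cccc(Cl)c2)cc(OC)c1OC`) gives 540 nM and compound 3 (`COc1cc(C(=O)c2cn(-c3ccccc3)cc2-c2ccc(Br)cc2)cc(OC)c1OC`) gives 340 nM on the same core. Compound 3 cannot be separated from either of the other two: the steps that reach it are a 1.8-fold higher number from compound 1 to compound 3 (0.25 log units; within the scatter) and a 1.6-fold lower number from compound 2 to compound 3 (0.20 log units; within the scatter) on these numbers. Only a 2.8-fold higher number from compound 1 to compound 2 (0.45 log units; beyond the scatter) goes beyond the scatter, and that step is modest.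

Compound 4 (`COc1cc(C(=O)c2cn(-c3ccccc3)cc2-c2cccc([N+](=O)[O-])c2)cc(OC)c1OC`) has 3-nitrophenyl in place of 4-bromophenyl on an aromatic carbon and has no number yet. Among the measured compounds shown here, no measured step makes this exact exchange. The closest by name is compound 2 with its 3-chlorophenyl, and the exchange of that group for 4-bromophenyl amounts to a 1.6-fold lower number from compound 2 to compound 3 (0.20 log units; within the scatter) in the data. On these data alone, all three aryl groups measured so far also fall within a narrow span, although a nitro-bearing ring is untested here. In this assay the expected step is a 1.3-fold higher number from compound 3 to compound 4 (0.12 log units; within the scatter) and thus none beyond the scatter. For compound 4 the expected value is 450 nM (estimated range 170 nM to 1200 nM).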

Compound 4, half-maximal inhibitory concentration: 50 nM
Estimate against measurement, compound 4: 9.0-fold (0.95 log units) above; measured number outside the range, below it.
By their numbers in this assay, from the lowest: compound 4; then compounds 1, 3 and 2 (each within the scatter of the next, the first and the last beyond it).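

Notes on this position: in this assay, the aryl group on this aromatic carbon of the shared core can shift the number further than the earlier compounds showed, since their only step beyond the scatter was modest (a 2.8-fold higher number from compound 1 to compound 2 (0.45 log units; beyond the scatter)), while 3-nitrophenyl gives clear drops from both compounds with other aryl groups (a 6.8-fold lower number from compound 3 to compound 4 (0.83 log units; beyond the scatter); a 3.8-fold lower number from compound 1 to compound 4 (0.58 log units; beyond the scatter)). The sharpest contrast is nitro in place of chloro on an otherwise unchanged compound (an 11-fold lower number from compound 2 to compound 4 (1.03 log units; beyond the scatter)), so a group at the ring place named in 3-chlorophenyl and 3-nitrophenyl does not by itself give a low number: compound 2 has the highest number of the four, and compound 4 has the lowest. Nothing available here bears on what lies behind this drop.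

Open: the compounds shown do not tell whether the low number is particular to nitro or would also appear with a nitrile, an amine or a carboxylic acid in its place. They also leave open whether the step would hold with a longer chain in place of the phenyl group on the ring atom two ring bonds from this position.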